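From compound 3 to compound 4: removing the bromines

This account rests on a few compounds, and the source may have more. Where it says the series, first, only, none or still open, it means among the compounds named here.

Of the compounds shown here, three sharing one core have been measured in a functional assay on A549 cells (Homo sapiens) for cytotoxicity, read by MTT assay, with a stated time of 72 h; on this read-out lower numbers stand for stronger inhibition and higher numbers for weaker inhibition. Compound 1 `N#Cc1ccc(/C=N/NC(=O)Nc2cc3c(Nc4ccc(F)c(Cl)c4)ncnc3cc2O[C@H]2CCOC2)cc1` gives 29100 nM, compound 2 `COc1cc(/C=N/NC(=O)Nc2cc3c(Nc4ccc(F)c(Cl)c4)ncnc3cc2O[C@H]2CCOC2)cc(OC)c1OC` gives 26400 nM, and compound 3 `O=C(N/N=C/c1cc(Br)c(O)c(Br)c1)Nc1cc2c(Nc3ccc(F)c(Cl)c3)ncnc2cc1O[C@H]1CCOC1` gives 8910 nM, the lowest of the three numbers. The change of a 1.1-fold lower number from compound 1 to compound 2 (0.04 log units; within the scatter) lies within the scatter. By contrast, a 3.3-fold lower number from compound 1 to compound 3 (0.51 log units; beyond the scatter) and a 3.0-fold lower number from compound 2 to compound 3 (0.47 log units; beyond the scatter) are modest but beyond it. So far, only the 3,5-dibromo-4-hydroxyphenyl of compound 3 stands apart.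

Compound 4 `O=C(N/N=C/c1ccc(O)cc1O)Nc1cc2c(Nc3ccc(F)c(Cl)c3)ncnc2cc1O[C@H]1CCOC1` alters that one group: 2,4-dihydroxyphenyl in place of 3,5-dibromo-4-hydroxyphenyl on a carbon with a double bond to nitrogen. It carries 2,4-dihydroxyphenyl in place of 3,5-dibromo-4-hydroxyphenyl on a carbon with a double bond to nitrogen. Among the measured compounds shown here, no measured compound carries this new group, so the evidence is indirect. The measured steps suggest that giving up the group of compound 3 could reverse much of a 3.0-fold lower number from compound 2 to compound 3 (0.47 log units; beyond the scatter). A modest rise is therefore expected, a 2.2-fold higher number from compound 3 to compound 4 (0.35 log units; beyond the scatter). The estimated value for compound 4 is 20000 nM, with an expected range of 8000 nM to 45000 nM.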

Compound 4, half-maximal inhibitory concentration: 9360 nM
For compound 4 the middle estimate is 2.1-fold (0.33 log units) above the measured one, within the range that was stated.
By their numbers in this assay, from the lowest: compounds 3 and 4 (each within the scatter of the next); then compounds 2 and 1 (each within the scatter of the next).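

In this assay, the bromines are not needed to reach the low numbers at this position: with 2,4-dihydroxyphenyl in place of 3,5-dibromo-4-hydroxyphenyl, the result is a 1.1-fold higher number from compound 3 to compound 4 (0.02 log units; within the scatter). Compound 4 also keeps the modest separation from the other two compounds, showing a 2.8-fold lower number from compound 2 to compound 4 (0.45 log units; beyond the scatter) and a 3.1-fold lower number from compound 1 to compound 4 (0.49 log units; beyond the scatter). Among these four compounds, the two lower numbers therefore belong to the rings carrying hydroxy groups, and none of the four goes against this, so compound 3 no longer stands alone.

Nothing measured here bears on why these two different rings give numbers within the scatter of each other. From the compounds shown here alone, it also remains open whether hydroxy groups themselves matter, which a phenyl ring bearing an amine or a carboxylic acid in their place could test.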